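The source may report more compounds than this note shows. Statements on the series, on what has been measured and on what is new or still open speak of the compounds shown alone.

Working notes on the series. The shared core is carried by compound 1 `CCn1c(=O)/c(=C2\Sc3ccccc3N2C)s/c1=C\c1ccncc1Nc1ccccc1F`, which in a functional assay on PC-3 cells (Homo sapiens) for inhibition (on this read-out higher numbers stand for weaker inhibition and lower numbers for stronger inhibition), gives 360 nM. Among the three measured compounds this places compound 1 second highest: compound 2 `CCn1c(=O)/c(=C2\Sc3ccccc3N2C)s/c1=C\c1ccncc1Nc1cc(C)ccc1C`, with its 2,5-dimethylphenyl on the ring nitrogen, gives 2000 nM in this assay, and compound 3 `CCn1c(=O)/c(=C2\Sc3ccc(C)cc3N2C)s/c1=C\c1ccncc1Nc1ccccc1F` gives 70 nM. The two measured steps are a 5.6-fold higher number from compound 1 to compound 2 (0.74 log units; beyond the scatter) and a 5.1-fold lower number from compound 1 to compound 3 (0.71 log units; beyond the scatter).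

Compound 4 `CCc1ccc2c(c1)S/C(=c1/s/c(=C\c3ccncc3Nc3ccccc3F)n(CC)c1=O)N2C` is the next member and has not yet been run in this assay. Relative to compound 1 the change is ethyl in place of hydrogen on an aromatic carbon. Within the data shown here, of the measured steps, only the one from compound 1 to compound 3 bears on this: there a methyl entered on an aromatic carbon of the same fused ring and gave a 5.1-fold lower number from compound 1 to compound 3 (0.71 log units; beyond the scatter). Compound 4 carries a larger alkyl on that ring, though its carbon is not the one that holds the methyl in compound 3, so the transfer is uncertain. A lower number beyond the scatter is nonetheless expected, in line with compound 3 and its 70 nM. Compound 4 is estimated at 120 nM, within 40 nM to 400 nM, which means an expected step of a 3.0-fold lower number from compound 1 to compound 4 (0.48 log units; beyond the scatter).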

Compound 4, half-maximal inhibitory concentration: 2200 nM
Beside the measured number, compound 4's estimate is 18-fold (1.26 log units) below it; the measured number lies above the stated range.
By their numbers in this assay, from the lowest: compound 3; then compound 1; then compounds 2 and 4 (each within the scatter of the next).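

In this assay ethyl in place of hydrogen gives a 6.1-fold higher number from compound 1 to compound 4 (0.79 log units; beyond the scatter) and so runs opposite to a 5.1-fold lower number from compound 1 to compound 3 (0.71 log units; beyond the scatter), with both steps beyond the scatter. An alkyl group on this six-membered aromatic ring therefore does not lower the number as a general matter: compound 4 goes against the trend suggested by compound 3. Compound 3 and compound 4 differ in both the group and the carbon that holds it, and nothing available explains the reversal.

Going by these compounds, whether the higher number follows the ethyl itself or the carbon it occupies stays open, and a methyl on that same carbon would separate the two. Whether this carbon accepts anything other than hydrogen without a higher number is also unsettled, and a methoxy or an amine there would test it.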